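The source may hold more compounds than are shown below. What is called first, only, known or untested is meant among the compounds shown, and "the series" means these compounds.

In a functional assay on HT-29 cells (Homo sapiens) for antiproliferative activity, read by sulforhodamine B assay, with a stated time of 48 h (on this read-out lower numbers stand for stronger inhibition and higher numbers for weaker inhibition), the series shares one core and varies the group on the sulfonate oxygen. Compound 1, `CCCN1CCN(c2ccc(S(=O)(=O)Oc3ccccc3C)cc2)C1=O`, gives > 100000 nM, which is a limit of the assay and not a number. Compound 2, `CCCN1CCN(c2ccc(S(=O)(=O)Oc3cccc([N+](=O)[O-])c3)cc2)C1=O`, gives > 100000 nM, which is also a limit. Compound 2 therefore has no readable position: the evidence is the limit of > 100000 nM in this assay, at which 2 of the 2 values shown sit. Compound 3, `CCCN1CCN(c2ccc(S(=O)(=O)Oc3ccc(F)cc3)cc2)C1=O`, carries 4-fluorophenyl in place of 3-nitrophenyl on an oxygen whose other neighbour is the sulfonyl sulfur: 4-fluorophenyl in place of 3-nitrophenyl on an oxygen. Within the data shown here, the only measured step that bears on this change is a step that the two limits leave unreadable from compound 1 to compound 2. It gives no size to carry over, and it shows only that neither of these two groups brought a reading within the range of this assay. With nothing to suggest a gain, no real movement is expected, although the limits leave the true size open. The expected change is a number no higher from compound 2 to compound 3 (the limit leaves the size open), and it is likely to be unreadable if another limit is reported. For compound 3 the estimated value is 100000 nM, with an expected range from 30000 nM to 300000 nM.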

Compound 3, half-maximal inhibitory concentration: 23000 nM
Compound 3: the middle estimate sits 4.3-fold (0.64 log units) above what was measured, and the stated range ends above it.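

In this assay, among these compounds, the group on the sulfonate oxygen turns out to be able to bring a reading within the range of the assay: of the three compounds, only the one carrying 4-fluorophenyl gives an actual number, with an at least 4.3-fold lower number from compound 2 to compound 3 (0.63 log units; beyond the scatter). Set against the other compound held at a limit, the same position gives an at least 4.3-fold lower number from compound 1 to compound 3 (0.63 log units; beyond the scatter), so the gain holds against both 3-nitrophenyl and 2-methylphenyl. Both steps give only a lower bound on the true size, because each starts from a compound that carries a limit: the limit of > 100000 nM in this assay, at which 2 of the 3 values shown sit.

As far as these compounds go, what remains open is whether the gain follows the fluorine atom itself or the way the ring is substituted, since 4-fluorophenyl differs from both other groups in the substituent it carries. The compounds shown also do not tell how a 4-chlorophenyl, a 4-methoxyphenyl or an unsubstituted phenyl on the same oxygen would read, and so whether compound 3 marks a trend or stands alone.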